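Methoxycarbonyl in place of 2-(methylamino)ethyl on compound 2

A few compounds are considered here, and "the series" means these few. Any claim that something is new, unique, unknown or untested is made for them only; others in the source may bear on it.

Of the compounds shown here, two on the shared core have been measured so far. In a functional assay on LNCaP cells (Homo sapiens) for cytotoxicity, read by MTT assay, with a stated time of 72 h (a higher number here means a weaker inhibitor, a lower number a stronger inhibitor), compound 1 (`O=C(NCc1ccc(F)cc1)c1nc(Br)c2cccnc2c1N1CCNCC1`) gives 4500 nM. In this assay compound 2 (`CNCCCNc1c(C(=O)NCc2ccc(F)cc2)nc(Br)c2cccnc12`) gives 8000 nM. Among the compounds with values here, these two values lie within the scatter of each other, so the numbers do not separate compound 2 from compound 1, the only other measured compound.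

The next compound is compound 3 (`COC(=O)CNc1c(C(=O)NCc2ccc(F)cc2)nc(Br)c2cccnc12`), which differs from compound 2 as follows: methoxycarbonyl in place of 2-(methylamino)ethyl on a saturated chain carbon bound to a nitrogen on an aromatic ring. The change is on a saturated chain carbon bound to a nitrogen on an aromatic ring, and the methylamino group of the chain is lost.

Within the data shown here, only one measured step bears on this, a 1.8-fold higher number from compound 1 to compound 2 (0.25 log units; within the scatter), with (3-(methylamino)propyl)amino in place of piperazin-1-yl. That step stays within the scatter, but both of its compounds keep an amine in the substituent, so it is a weak guide to an ester. No shift beyond the scatter is expected in this assay, with wide uncertainty. The expected step is a 1.1-fold higher number from compound 2 to compound 3 (0.05 log units; within the scatter). For compound 3 the estimated value is 9000 nM, with an expected range of 3000 nM to 30000 nM.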

Compound 3, half-maximal inhibitory concentration: 5000 nM
Compound 3: middle estimate off by 1.8-fold (0.26 log units), on the high side; measured number inside the range.
By their numbers in this assay, from the lowest: compounds 1, 3 and 2 (each within the scatter of the next).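

Replacing 2-(methylamino)ethyl with methoxycarbonyl on a saturated chain carbon bound to a nitrogen on an aromatic ring gives a 1.6-fold lower number from compound 2 to compound 3 (0.20 log units; within the scatter) in this assay, so the numbers do not separate the chain that carries the methylamino group from the one that carries the ester. The earlier pair had an amine in both substituents, whereas the second new step, a 1.1-fold higher number from compound 1 to compound 3 (0.05 log units; within the scatter), sets ((methoxycarbonyl)methyl)amino against piperazin-1-yl and shows that the values of compound 1 and compound 3 are not separated either, so keeping an amine in the substituent is not needed for a value in this range among these three compounds. No measurement at hand accounts for this flat reading at the position.

On these data alone, whether a carboxylic acid in place of the methoxycarbonyl, or a longer chain ending in the same group, would give a step beyond the scatter in this assay remains open. Also open, as far as these compounds go, is whether any substituent at this place on the shared core can separate itself from compound 1, compound 2 and compound 3 at all.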